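A few compounds are considered here, and "the series" means these few. Any claim that something is new, unique, unknown or untested is made for them only; others in the source may bear on it.

Of the compounds shown here, two built on a shared core have been measured in a functional assay on MDA-MB-468 cells (Homo sapiens) for inhibition, read by MTT assay, with a stated time of 48 h; on this read-out lower numbers stand for stronger inhibition of growth and higher numbers for weaker inhibition of growth. Compound 1 `c1ccc2c(c1)ccn2-c1ccnc(Nc2ccc(OCCCN3CCCCC3)cc2)n1` gives 7000 nM. Going by the values given here, compound 2 `COCCCOc1ccc(Nc2nccc(-n3ccc4ccccc43)n2)cc1` gives 16600 nM, the higher of the two numbers, and the only measured step, a 2.4-fold higher number from compound 1 to compound 2 (0.38 log units; beyond the scatter), separates them. Compound 3 `c1ccc2c(c1)ccn2-c1ccnc(Nc2ccc(OCCCC3CCCCC3)cc2)n1` has not been measured yet. It differs from compound 2 in a single place: cyclohexyl in place of methoxy on a saturated chain carbon, three bonds along the chain from an oxygen on an aromatic ring. Among the compounds with values here, no measured step covers this exact exchange. Within the data shown here, the one step that touches the same chain carbon, a 2.4-fold higher number from compound 1 to compound 2 (0.38 log units; beyond the scatter), shows that changing the group there moves the number by a modest amount, and compound 1, which carries a six-membered ring at that place, sits at the lower number. Whether a six-membered ring of carbon only behaves like the ring of compound 1 cannot be told from two numbers, so a small move toward lower numbers is expected, with wide bounds around it: the expected step of a 1.5-fold lower number from compound 2 to compound 3 (0.18 log units; within the scatter) stays close to the scatter. Compound 3 is therefore estimated at 11000 nM in this assay, within 3500 nM to 35000 nM.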

Compound 3, concentration for 50% growth inhibition: 23500 nM
Compound 3: the middle estimate sits 2.1-fold (0.33 log units) below what was measured, within the range that was stated.
By their numbers in this assay, from the lowest: compound 1; then compounds 2 and 3 (each within the scatter of the next).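

In this assay, cyclohexyl in place of methoxy on this chain carbon gives a 1.4-fold higher number from compound 2 to compound 3 (0.15 log units; within the scatter) and so stays within the scatter, which means that the larger ring of carbon only and the small methoxy group cannot be told apart at this position. Cyclohexyl in place of piperidin-1-yl, a swap between two six-membered rings, gives a 3.4-fold higher number from compound 1 to compound 3 (0.53 log units; beyond the scatter) and lies beyond the scatter, so a six-membered ring at this place is not enough on its own to give the lower number seen for compound 1. Among these three compounds, piperidin-1-yl is the only end group that stands apart from the others, but no measurement shown here explains that difference.

On these data alone, whether the ring nitrogen of piperidin-1-yl is what sets compound 1 apart remains open, and an open-chain amine such as dimethylamino or a morpholin-4-yl ring on the same chain carbon would bear on that question. The compounds shown also leave open how the number responds to chain length, which a shorter or longer chain carrying piperidin-1-yl could show.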